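Swapping the amide aryl group in a urea series

A few compounds are considered here, and "the series" means these few. Any claim that something is new, unique, unknown or untested is made for them only; others in the source may bear on it.

Two compounds of a shared core have been run in an ADME assay on microsomes from liver (Mus musculus) for metabolic stability; a higher number here means that the compound lasts longer, a lower number that the compound disappears faster. Compound 1 `Cc1cc(C(=O)Nc2ccc(F)cn2)ccc1N(CCN1CCCC1)C(=O)Nc1ccc(Cl)cc1` gives 0.437 h. Compound 2 `Cc1cc(C(=O)Nc2ccc(Cl)cc2)ccc1N(CCN1CCCC1=O)C(=O)Nc1ccc(Cl)cc1` gives 0.147 h, the lower of the two numbers; compound 1 sits higher, a gap beyond the usual scatter. Within the data shown here, compound 1 and compound 2 differ in two places at once, so their two numbers show only that, and no single step between them is counted.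

Compound 3 `Cc1cc(C(=O)Nc2ccc(F)cn2)ccc1N(CCN1CCCC1=O)C(=O)Nc1ccc(Cl)cc1` has not yet been measured. It follows compound 2 with one change: 5-fluoropyridin-2-yl in place of 4-chlorophenyl on an amide-type nitrogen. The rest of compound 3, including the pyrrolidinone-bearing chain, is that of compound 2.

Among the measured compounds shown here, no measured pair isolates this change, so the expectation rests on the two values alone. The step from compound 2 to compound 3 is expected to be a 1.7-fold higher number from compound 2 to compound 3 (0.23 log units; within the scatter), a modest rise that may well stay within the scatter, given that compound 1, which carries the same 5-fluoropyridin-2-yl group, gives 0.437 h. Compound 3 is therefore estimated at 0.25 h, with a range from 0.1 h to 0.6 h in this assay .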

Compound 3, half-life: 0.0617 h
Estimate against measurement, compound 3: 4.1-fold (0.61 log units) above; the measured number lies below the stated range.
By their numbers in this assay, from the lowest: compound 3; then compound 2; then compound 1.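

In this assay, 5-fluoropyridin-2-yl in place of 4-chlorophenyl on an amide-type nitrogen, with the pyrrolidinone-bearing chain held constant, gives a 2.4-fold lower number from compound 2 to compound 3 (0.38 log units; beyond the scatter) and so does not bring the higher number of compound 1 with it. Among these compounds, compound 3 also isolates the chain for the first time: with 5-fluoropyridin-2-yl kept, 2-oxopyrrolidin-1-yl in place of pyrrolidin-1-yl on a saturated chain carbon gives a 7.1-fold lower number from compound 1 to compound 3 (0.85 log units; beyond the scatter) in this series. Both steps lie beyond the scatter and both run downward, so among these three compounds each change, read alone, goes with a shorter half-life, and the chain change gives the larger step.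

Nothing measured here accounts for either step. From the compounds shown here alone, how 4-chlorophenyl on the amide-type nitrogen would read with the pyrrolidin-1-yl chain remains open, as does where a morpholine in place of pyrrolidin-1-yl would fall in this assay when paired with either amide group.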